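A few compounds are considered here, and "the series" means these few. Any claim that something is new, unique, unknown or untested is made for them only; others in the source may bear on it.

Measured in a functional assay on ileum (Cavia porcellus) for antagonist activity; a higher number here means a weaker inhibitor, a lower number a stronger inhibitor:
compound 1 `CC(=O)c1ccc(OCCCOc2ccc3c(O)c([N+](=O)[O-])c(=O)oc3c2)cc1O`: 2800 nM
compound 2 `CCc1ccccc1OCC(O)COc1ccc2c(O)c([N+](=O)[O-])c(=O)oc2c1`: 2700 nM
compound 3 `CC(=O)c1ccc(OCC(O)COc2ccc3c(O)c([N+](=O)[O-])c(=O)oc3c2)cc1O`: > 20000 nM

Compound 3 gives only a limit, > 20000 nM, and not a number. The steps of an at least 7.1-fold higher number from compound 1 to compound 3 (0.85 log units; beyond the scatter) and an at least 7.4-fold higher number from compound 2 to compound 3 (0.86 log units; beyond the scatter) both lie beyond the scatter, so it is the weakest of the three. Compound 4 `CC(=O)c1ccc(OCC(O)COc2ccc3c(O)c([N+](=O)[O-])c(=O)oc3c2)c(C)c1O` carries methyl in place of hydrogen on an aromatic carbon, ortho to a hydroxy group (methyl in place of hydrogen on an aromatic carbon). Among the measured compounds shown here, the most relevant evidence is an at least 7.4-fold higher number from compound 2 to compound 3 (0.86 log units; beyond the scatter), which shows that changing this aromatic group can shift the number, although no measured step adds this methyl itself. A move to a lower number is therefore expected, but a small one, and another limit remains possible. The expected change is an at least 2.8-fold lower number from compound 3 to compound 4 (0.45 log units; beyond the scatter). For compound 4 the estimated value is 7000 nM, with an expected range of 2000 nM to 20000 nM.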

Compound 4, half-maximal inhibitory concentration: 500 nM
Beside the measured number, compound 4's estimate is 14-fold (1.15 log units) above it, outside the stated range (below it).
By their numbers in this assay, from the lowest: compound 4; then compounds 2 and 1 (each within the scatter of the next). At a limit, above all of these: compound 3.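

In this assay, methyl in place of hydrogen on an aromatic carbon, ortho to a hydroxy group, gives an at least 40-fold lower number from compound 3 to compound 4 (1.60 log units; beyond the scatter). The earlier steps shown here changed a whole aromatic group or a hydroxy on the chain, whereas this one shows that a single added carbon at this position can move the number beyond the scatter. Compound 3 stands at a limit and not at a number: the limit of > 20000 nM in this assay, at which 1 of the 4 values shown sits.

On these data alone, whether an amine or a longer chain at this position would act like methyl remains open. So does whether methyl would give a similar step on the chain of compound 1, which lacks the hydroxy.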